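Swapping Methoxy for Fluoro on a Shared Core

This account rests on a few compounds, and the source may have more. Where it says the series, first, only, none or still open, it means among the compounds named here.

Compound 1 `CCOC(=O)C1=C(C)NC(=S)NC1c1ccc(OC)cc1`: 3.2 ug/mL
Compound 2 `CCOC(=O)C1=C(C)NC(=S)NC1C1CCCCC1`: 24.1 ug/mL

Of the compounds shown here, two have been measured in a functional assay on NCI/ADR-RES cells (Homo sapiens) for inhibition, read by sulforhodamine B assay, with a stated time of 48 h; a higher number here means a weaker inhibitor of growth, a lower number a stronger inhibitor of growth. Compound 1 gives 3.2 ug/mL, the lowest of the two numbers, and compound 2 gives 24.1 ug/mL, a number that lies beyond the usual scatter from compound 1. Within the data shown here, no pair of measured compounds differs in only one place, so the change leading to compound 3 `CCOC(=O)C1=C(C)NC(=S)NC1c1ccc(F)cc1` has no direct calibration. Compound 3 differs from compound 1 by fluoro in place of methoxy on an aromatic carbon. Because compound 1 gives 3.2 ug/mL and compound 3 keeps the same six-membered aromatic ring, the expectation for compound 3 is a small step at most, likely within the scatter, with a slight lean toward a higher number. The estimate for compound 3 in this assay is 4.5 ug/mL, within a range from 1.5 ug/mL to 14 ug/mL, which corresponds to an expected step of a 1.4-fold higher number from compound 1 to compound 3 (0.15 log units; within the scatter).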

Compound 3, concentration for 50% growth inhibition: 26.1 ug/mL
For compound 3 the middle estimate is 5.8-fold (0.76 log units) below the measured one, outside the stated range (above it).
By their numbers in this assay, from the lowest: compound 1; then compounds 2 and 3 (each within the scatter of the next).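

Fluoro in place of methoxy on an aromatic carbon, para to a large group, is a change in one place only, and in this assay it gives an 8.2-fold higher number from compound 1 to compound 3 (0.91 log units; beyond the scatter). This first one-place step shows that the group at this position matters: keeping the six-membered aromatic ring is not enough to preserve the lower number of compound 1. Nothing available here explains why the step is this large.

A single step cannot tell whether the higher number comes with the loss of methoxy or with the arrival of fluoro. Also open, as far as these compounds go, is whether an ethoxy group, a chlorine atom or an amine at this same position would stay close to compound 1 or move as far as compound 3.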